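Removing a methyl from a methoxy group on two cores

The compounds below may be only part of what the source reports. "The series", "measured", "known", "first", "only" and "open" are said of these compounds alone.

Compound 1 `O=C(Nc1cccc(O)c1)C1NCCc2ccccc21`: in a functional assay on NUGC-3 cells (Homo sapiens) for inhibition, read by sulforhodamine B assay, with a stated time of 48 h (a lower number here means a stronger inhibitor of growth, a higher number a weaker inhibitor of growth), compound 1 gives > 10000 nM, a limit of the assay rather than a number.
Compound 2 `COc1ccc(NC(=O)c2nccc3ccccc23)cc1`: in this assay compound 2 gives > 10000 nM, again a limit.
Compound 3 `COc1cccc(NC(=O)C2NCCc3ccccc32)c1`: in this assay compound 3 gives > 10000 nM, also a limit.

Compound 3 and compound 1 share a core and differ by hydrogen in place of methyl on an oxygen on an aromatic ring; the step from compound 3 to compound 1 is a step that the two limits leave unreadable from compound 3 to compound 1. Compound 2 carries a different core, and the difference between the two cores is not broken down here. Compound 4 `O=C(Nc1ccc(O)cc1)c1nccc2ccccc12` has not yet been measured; it differs from compound 2 by hydrogen in place of methyl on an oxygen on an aromatic ring, the same change at the same kind of place. Compound 4 is expected to show a step that the limit leaves unreadable from compound 2 to compound 4 in this assay, since every measured value rests at the limit of > 10000 nM in this assay, at which 3 of the 3 values shown sit. Compound 4 is therefore estimated at 15000 nM, between 5000 nM and 50000 nM, and will most likely also come back as a limit.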

Compound 4, concentration for 50% growth inhibition: > 10000 nM
Compound 4: no number, only a limit; the forecaster's own chance of this, stated with the estimate: 85%; the middle value lies beyond the limit too.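

No step can be read from compound 2 to compound 4, since both results are limits rather than numbers: the limit of > 10000 nM in this assay, at which 4 of the 4 values shown sit.

The compounds shown leave open whether methoxy to hydroxy changes growth inhibition on either core, and which structure would give a readable number in this assay.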